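This account rests on a few compounds, and the source may have more. Where it says the series, first, only, none or still open, it means among the compounds named here.

Measured compounds:
- Compound 1, `COc1ccc(-n2nncc2CN2C(=O)C3(C(C#N)=C(N)Oc4c3c3nc5ccccc5nc3c3ccccc43)c3ccccc32)cc1`, in a functional assay on A549 cells (Homo sapiens) for antiproliferative activity, read by MTT assay, with a stated time of 48 h; on this read-out higher numbers stand for weaker inhibition and lower numbers for stronger inhibition: > 50000 nM
- Compound 2, `CC(=O)Nc1ccc(-n2nncc2CN2C(=O)C3(C(C#N)=C(N)Oc4c3c3nc5ccccc5nc3c3ccccc43)c3ccccc32)cc1`: > 50000 nM
- Compound 3, `CC(=O)Nc1ccc(-n2nncc2CN2C(=O)C3(C(C#N)=C(N)Oc4c(N)cc5nc6ccccc6nc5c43)c3ccccc32)cc1`: > 50000 nM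

Each of these values is a limit of this assay, not a number. Compound 1 reached only the limit > 50000 nM. Compound 2 likewise reached only the limit > 50000 nM. Compound 3 also gave only the limit > 50000 nM. All three sit at the limit of > 50000 nM in this assay, at which 3 of the 3 values shown sit, so none of them shows measurable inhibition of cell growth within the tested range.

Compounds 1 and 2 share a core and differ in one place: methoxy in place of acetamido on an aromatic carbon. Because both end at a limit, the step that the two limits leave unreadable from compound 2 to compound 1 cannot be read; it is not known whether the change helped, hurt or did nothing.

Compound 4, `COc1ccc(-n2nncc2CN2C(=O)C3(C(C#N)=C(N)Oc4c(N)cc5nc6ccccc6nc5c43)c3ccccc32)cc1`, has not been measured. It carries the core of compound 3; the difference between the two cores of compound 2 and compound 3 is not broken down here. From compound 3 to compound 4 the change is methoxy in place of acetamido on an aromatic carbon, the same change as from compound 2 to compound 1, at the same place.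

Within the data shown here, the only guide for compound 4 is the pair compound 2 and compound 1, where the same change left the result at the limit, and compound 3 itself at the limit > 50000 nM. It is therefore expected that compound 4 most likely also reaches only a limit in this assay, with the estimated step that the limit leaves unreadable from compound 3 to compound 4 carrying wide uncertainty. The estimate for compound 4 is 80000 nM, expected to lie between 15000 nM and 400000 nM.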

Compound 4, half-maximal inhibitory concentration: > 50000 nM
Compound 4 ended at the assay's limit; the forecaster's own chance of this, stated with the estimate: 85%; the middle value is on the limit's open side.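

As far as these compounds go, no new step can be read: in this assay, compound 3 and compound 4 both end at a limit rather than a number, so the size of the change from 4-acetamidophenyl to 4-methoxyphenyl stays unknown. All the compounds shown end at the same point: the limit of > 50000 nM in this assay, at which 4 of the 4 values shown sit. The compounds shown leave open whether this change of group, or the difference between the two cores, affects inhibition of cell growth at all.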